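The compounds below may be only part of what the source reports. "The series", "measured", "known", "first", "only" and "open" are said of these compounds alone.

Working notes. In a functional assay on HeLa cells (Homo sapiens) for cytotoxicity, read by MTT assay, with a stated time of 48 h, in the absence of a further agent (on this read-out lower numbers stand for stronger inhibition and higher numbers for weaker inhibition), compound 1 `COc1ccc2[nH]cc(-c3nc(C(=O)Nc4cc(OC)c(OC)c(OC)c4)cs3)c2c1` gives 29600 nM, compound 2 `COc1cc(NC(=O)c2csc(-c3c[nH]c4ccc(Br)cc34)n2)cc(OC)c1OC` gives 55800 nM and compound 3 `COc1cc(NC(=O)c2csc(-c3cn(Cc4ccc(Cl)cc4)c4ccccc34)n2)cc(OC)c1OC` gives 91400 nM. Within the data shown here, on these numbers compound 2 sits with compound 1 and compound 3 all within the scatter of one another; no measured step here reaches beyond it. Compound 4 `COc1cc(NC(=O)c2csc(-c3c[nH]c4ccc(F)cc34)n2)cc(OC)c1OC` differs from compound 2 by fluoro in place of bromo on an aromatic carbon. Among the measured compounds shown here, the one measured step at this position, a 1.9-fold higher number from compound 1 to compound 2 (0.28 log units; within the scatter), stays within the scatter, and no measured step covers fluoro against bromo. For compound 4 in this assay no step beyond the scatter is therefore expected, the expected step being a 1.1-fold lower number from compound 2 to compound 4 (0.05 log units; within the scatter). The estimate for compound 4 is 50000 nM, with a range from 18000 nM to 140000 nM.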

Compound 4, half-maximal inhibitory concentration: > 100000 nM
Compound 4: a limit, no number; the forecaster's own chance of this, stated with the estimate: 10%; middle value at least 2.0-fold (0.30 log units) from the limit.
By their numbers in this assay, from the lowest: compounds 1, 2 and 3 (each within the scatter of the next, the first and the last beyond it). At a limit, above all of these: compound 4.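

In this assay compound 4 stands at a limit, > 100000 nM, not at a number. Among these compounds, this position now shows a step beyond the scatter, with fluoro in place of methoxy giving an at least 3.3-fold higher number from compound 1 to compound 4 (0.52 log units; beyond the scatter), where the earlier compounds showed none. With fluoro in place of bromo the floor of the step, an at least 1.7-fold higher number from compound 2 to compound 4 (0.25 log units; that floor lies within the scatter), stays within the scatter, so these two groups cannot yet be ordered at this position. Open, as far as these compounds go, is whether an amine or a carboxylic acid here would give a lower number than methoxy does.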